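Nitro in place of carbamoyl: next step in the series

The source may report more compounds than this note shows. Statements on the series, on what has been measured and on what is new or still open speak of the compounds shown alone.

In a functional assay on HT-29 cells (Homo sapiens) for inhibition, read by MTT assay (a higher number here means a weaker inhibitor, a lower number a stronger inhibitor), compound 1 (`COc1ccc(/C=C2\c3cc(OC)c(OC)c(OC)c3CC[C@@H]2O)cc1F`) gives 3 nM, compound 2 (`COc1ccc(/C=C2\c3cc(OC)c(OC)c(OC)c3CC[C@@H]2O)cc1O`) gives 260 nM and compound 3 (`COc1ccc(/C=C2\c3cc(OC)c(OC)c(OC)c3CC[C@@H]2O)cc1C(N)=O`) gives 550 nM. Compound 3 thus has the highest number of the three and is the weakest inhibitor measured so far.

Compound 4 (`COc1ccc(/C=C2\c3cc(OC)c(OC)c(OC)c3CC[C@@H]2O)cc1[N+](=O)[O-]`) keeps the shared core and carries nitro in place of carbamoyl on an aromatic carbon.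

Within the data shown here, three measured steps concern this same carbon. Two were large, an 87-fold higher number from compound 1 to compound 2 (1.94 log units; beyond the scatter) and a 180-fold higher number from compound 1 to compound 3 (2.26 log units; beyond the scatter), and both start from fluoro. The third, between hydroxy and carbamoyl, was modest: a 2.1-fold higher number from compound 2 to compound 3 (0.33 log units; beyond the scatter). Among the measured compounds shown here, no measured compound carries nitro, so the direction rests on weak ground. Compound 3 sits at the top of the measured range, which leaves more room for a fall than for a rise, though a number as low as that of compound 1 is not expected.

The expected change is modest and towards a lower number, a 2.8-fold lower number from compound 3 to compound 4 (0.44 log units; beyond the scatter). The estimate for compound 4 is 200 nM, with an expected range of 30 nM to 900 nM.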

Compound 4, half-maximal inhibitory concentration: 1590 nM
The estimate for compound 4 lay 8.0-fold (0.90 log units) below the measured number; measured number outside the range, above it.
By their numbers in this assay, from the lowest: compound 1; then compound 2; then compound 3; then compound 4.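

In this assay nitro does not fall within the range already seen at this aromatic carbon but extends it upward, with a 2.9-fold higher number from compound 3 to compound 4 (0.46 log units; beyond the scatter) and a 6.1-fold higher number from compound 2 to compound 4 (0.79 log units; beyond the scatter) setting compound 4 as the weakest inhibitor of the four. The largest change comes against fluoro, with a 530-fold higher number from compound 1 to compound 4 (2.72 log units; beyond the scatter) widening the gap that already separated fluoro from hydroxy and carbamoyl. Fluoro therefore remains alone at the low end, and the three other groups all lie far above it, with nitro highest. Nothing on hand gives a reason for this order among the four groups.

Open, as far as these compounds go, is whether chloro, methyl or a nitrile on this carbon would give a number close to that of compound 1 or one close to the other three. Also open, from the compounds shown here alone, is whether the order of the four groups would hold on another cell line.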